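Swapping 3-nitrophenyl for 2-bromophenyl on the shared core

The source may report more compounds than this note shows. Statements on the series, on what has been measured and on what is new or still open speak of the compounds shown alone.

In a functional assay on MCF7 cells (Homo sapiens) for antiproliferative activity, read by MTT assay, with a stated time of 48 h (a higher number here means a weaker inhibitor, a lower number a stronger inhibitor), compound 2 `CCOC(=O)/C(=C/c1ccccc1)CN1C(=O)[C@@H](OC)[C@H]1c1cccc([N+](=O)[O-])c1` gives 19900 nM. This lies within the usual scatter of the other two measured compounds: compound 1 `CCOC(=O)/C(=C/c1ccccc1)CN1C(=O)[C@@H](OC)[C@H]1c1ccc(Cl)cc1` gives 12700 nM, and compound 3 `COC(=O)/C(=C/c1ccccc1)CN1C(=O)[C@@H](OC)[C@H]1c1cccc(F)c1` gives 13700 nM.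

Compound 4 `CCOC(=O)/C(=C/c1ccccc1)CN1C(=O)[C@@H](OC)[C@H]1c1ccccc1Br` has not yet been measured. It carries 2-bromophenyl in place of 3-nitrophenyl on a saturated ring carbon, next to the ring nitrogen: 2-bromophenyl in place of 3-nitrophenyl on a saturated ring carbon.

Going by the values given here, one measured step bears directly on this change. It replaces the group at the same place and shows a 1.6-fold higher number from compound 1 to compound 2 (0.20 log units; within the scatter). Compound 3 has a different ester as well as a different phenyl group, so it offers only loose support. Among the compounds with values here, no measured compound carries 2-bromophenyl, which keeps the range wide.

No step beyond the scatter is therefore expected in this assay. The estimated step is a 1.3-fold lower number from compound 2 to compound 4 (0.12 log units; within the scatter). For compound 4 the expected value is 15000 nM, with an estimated range from 6500 nM to 32000 nM.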

Compound 4, half-maximal inhibitory concentration: 5790 nM
Beside the measured number, compound 4's estimate is 2.6-fold (0.41 log units) above it; the measured number lies below the stated range.
By their numbers in this assay, from the lowest: compound 4; then compounds 1, 3 and 2 (each within the scatter of the next).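

Placing 2-bromophenyl on the saturated ring carbon next to the ring nitrogen gives a 3.4-fold lower number from compound 2 to compound 4 (0.54 log units; beyond the scatter) in this assay and, measured against 4-chlorophenyl, a 2.2-fold lower number from compound 1 to compound 4 (0.34 log units; beyond the scatter) as well. Both steps are modest but lie beyond the scatter, whereas the earlier swap at this same carbon gave a 1.6-fold higher number from compound 1 to compound 2 (0.20 log units; within the scatter) and stayed within it. The group at this place can therefore shift the number, at least among compound 1, compound 2 and compound 4.

As far as these compounds go, whether the shift belongs to the bromine itself or to where it sits on the phenyl ring stays open, as does how a plain phenyl, or a phenyl carrying an amine or a carboxylic acid, would behave at this carbon. No measurement among the data at hand accounts for the step.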